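Ethylsulfamoyl to Chloro-Sulfamoyl: Expected Kinase Binding

The source may hold more compounds than are shown below. What is called first, only, known or untested is meant among the compounds shown, and "the series" means these compounds.

Measured compounds:
compound 1 `CCCS(=O)(=O)Nc1ccc(F)c(C(=O)c2n[nH]c3ncc(-c4ccc(C)c(C)c4)cc23)c1F` gives 20% in an assay for binding affinity to dual specificity mitogen-activated protein kinase kinase 4 (Homo sapiens), read by KINOMEscan, tested at 100 nM; on this read-out lower numbers stand for a stronger effect and higher numbers for a weaker effect at the one concentration tested
compound 2 `CCCS(=O)(=O)Nc1ccc(F)c(C(=O)c2n[nH]c3ncc(-c4ccc(S(=O)(=O)NC)cc4)cc23)c1F` gives 1.2% in this assay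
compound 3 `CCCS(=O)(=O)Nc1ccc(F)c(C(=O)c2n[nH]c3ncc(-c4ccc(S(=O)(=O)NCC)cc4)cc23)c1F` gives 3% in this assay

Compound 3 stands second highest of the three numbers. Its nearest neighbour is compound 2, separated by a number 1.8 percentage points higher from compound 2 to compound 3 (within the scatter), a gap within the scatter. The furthest is compound 1, with a number 17 percentage points lower from compound 1 to compound 3 (beyond the scatter).

Compound 4 `CCCS(=O)(=O)Nc1ccc(F)c(C(=O)c2n[nH]c3ncc(-c4ccc(S(N)(=O)=O)cc4Cl)cc23)c1F` differs from compound 3 in one place: 2-chloro-4-sulfamoylphenyl in place of 4-(ethylsulfamoyl)phenyl on an aromatic carbon. Two kinds of measured step bear on this. The steps of a number 18.8 percentage points lower from compound 1 to compound 2 (beyond the scatter) and a number 17 percentage points lower from compound 1 to compound 3 (beyond the scatter) show that a 4-(methylsulfamoyl)phenyl or a 4-(ethylsulfamoyl)phenyl in place of 3,4-dimethylphenyl gives clearly lower numbers, while a number 1.8 percentage points higher from compound 2 to compound 3 (within the scatter) shows that changing the group on the sulfonamide nitrogen stays within the scatter. For the measured compounds named here, compound 4 keeps a sulfamoyl-bearing phenyl, now as 2-chloro-4-sulfamoylphenyl; no measured step covers the chlorine. The expected step is therefore no change at the digits printed from compound 3 to compound 4 (within the scatter), not beyond the scatter. Compound 4 is expected to give about 3%, in the range 0.8% to 12%.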

Compound 4, a percentage reported as activity, at one concentration (the size of the read-out at that concentration, not a potency): 3.4%
The estimate for compound 4 lay 0.4 percentage points below the measured number; measured number inside the range.
By their numbers in this assay, from the lowest: compounds 2, 3 and 4 (each within the scatter of the next); then compound 1.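

In this assay the 2-chloro-4-sulfamoylphenyl group stays within the scatter of both alkylated sulfamoyl groups, with a number 0.4 percentage points higher from compound 3 to compound 4 (within the scatter) and a number 2.2 percentage points higher from compound 2 to compound 4 (within the scatter) on the printed values, yet it remains apart from the 3,4-dimethylphenyl group, with a number 16.6 percentage points lower from compound 1 to compound 4 (beyond the scatter) as the step. At this aromatic carbon, then, a sulfamoyl-bearing phenyl with no alkyl group on the sulfonamide nitrogen and with a chlorine on the ring gives a number in the same range as the two alkylated ones. No measured evidence accounts for these numbers.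

The two changes arrive together, so the compounds shown leave open what the chlorine and the missing alkyl group each contribute alone. They also leave open whether a carboxylic acid or an amine in place of the sulfamoyl group, or a butyl chain on its nitrogen, would stay in this range.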